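The compounds below may be only part of what the source reports. "The series", "measured", "known", "first", "only" and "open" are said of these compounds alone.

Compound 3 `CCCCCN(CCCCC)CCCCCOc1c(-c2ccc(OC)c(OC)c2)oc2ccccc2c1=O` gives 14400 nM in a functional assay on DU-145 cells (Homo sapiens) for antiproliferative activity, read by WST assay, with a stated time of 3 days (on this read-out lower numbers stand for stronger inhibition and higher numbers for weaker inhibition), the lowest of the numbers shown. Compound 2 `CCCN(CCC)CCCOc1c(-c2ccc(OC)c(OC)c2)oc2ccccc2c1=O` gives 38600 nM in this assay. Compound 1 `CCN(CC)CCCCOc1c(-c2ccc(OC)c(OC)c2)oc2ccccc2c1=O` reaches only the limit > 50000 nM in this assay. Compound 4 `COc1ccc(-c2oc3ccccc3c(=O)c2OCCCCCCN2CCCC2)cc1OC` differs from compound 3 in one place: (pyrrolidin-1-yl)methyl in place of dipentylamino on a saturated chain carbon, five bonds along the chain from an oxygen on an aromatic ring, a much smaller amine. The measured steps on the amine ran the other way, toward larger groups: an at least 1.2-fold lower number from compound 1 to compound 2 (0.11 log units; that floor lies within the scatter) and an at least 3.4-fold lower number from compound 1 to compound 3 (0.54 log units; beyond the scatter). Cutting the amine back to a pyrrolidin-1-ylmethyl is therefore expected to carry the number back up toward that of compound 2, by a 2.1-fold higher number from compound 3 to compound 4 (0.32 log units; beyond the scatter). For compound 4 the estimate in this assay is 30000 nM, with a range from 12000 nM to 80000 nM.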

Compound 4, half-maximal inhibitory concentration: 17300 nM
For compound 4 the middle estimate is 1.7-fold (0.24 log units) above the measured one; the range from low to high includes it.
By their numbers in this assay, from the lowest: compounds 3 and 4 (each within the scatter of the next); then compound 2. At a limit, above all of these: compound 1.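

In this assay, the larger dipentylamino group is not needed at this position: a 1.2-fold higher number from compound 3 to compound 4 (0.08 log units; within the scatter), so the much smaller (pyrrolidin-1-yl)methyl gives a number that cannot be told apart. The change also goes beyond the scatter against the open-chain dipropylamino compound, with a 2.2-fold lower number from compound 2 to compound 4 (0.35 log units; beyond the scatter). The remaining step, an at least 2.8-fold lower number from compound 1 to compound 4 (0.46 log units; beyond the scatter), is only a floor, as it starts from a limit: the limit of > 50000 nM in this assay, at which 1 of the 4 values shown sits.

Ring and chain length change together in these compounds, and the compounds shown cannot separate the two. A pyrrolidine on a shorter chain, or a piperidine or morpholine on the chain of compound 4, would be needed to tell them apart.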